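A few compounds are considered here, and "the series" means these few. Any claim that something is new, unique, unknown or untested is made for them only; others in the source may bear on it.

Measured compounds, with growth inhibition in a functional assay on KM12 cells (Homo sapiens) for inhibition; a lower number here means a stronger inhibitor of growth, a higher number a weaker inhibitor of growth:
compound 1 `COc1cc(/C=C/C(=O)c2cccc(-n3cc(-c4ccccc4)[nH]c3=O)c2)cc(OC)c1OC` gives 1370 nM
compound 2 `COc1cc(/C=C/C(=O)c2cccc(-n3cc(-c4ccccc4)[nH]c3=O)c2)ccc1O` gives 1610 nM

Compound 1 stands at the lower of the two numbers, but the gap to compound 2 is within the scatter, so the two cannot be told apart on this evidence. Compound 3 `COc1ccc(-c2cn(-c3cccc(C(=O)/C=C/c4cc(OC)c(OC)c(OC)c4)c3)c(=O)[nH]2)cc1` has not yet been measured in this assay. It differs from compound 1 in one place: methoxy in place of hydrogen on an aromatic carbon. Among the measured compounds shown here, no measured pair carries this change, so its effect cannot be read off from the data at hand. The expectation is a small step in this assay, with no clear direction and not beyond the scatter. For compound 3 the estimated value is 1200 nM, with a range of 450 nM to 3200 nM. The step this estimate means, a 1.1-fold lower number from compound 1 to compound 3 (0.06 log units; within the scatter), is expected to stay within the scatter.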

Compound 3, concentration for 50% growth inhibition: 1420 nM
Beside the measured number, compound 3's estimate is 1.2-fold (0.07 log units) below it; low and high end bracket the measured number.
By their numbers in this assay, from the lowest: compounds 1, 3 and 2 (each within the scatter of the next).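

Methoxy in place of hydrogen on this aromatic carbon, para to a large group, gives a 1.0-fold higher number from compound 1 to compound 3 (0.02 log units; within the scatter) in this assay, so phenyl and 4-methoxyphenyl cannot be told apart at this position on this read-out. Among the compounds shown here, compound 1 and compound 2 both carry hydrogen here, so only this pair gives a reading of the position, and it shows that a methoxy group can stand there with growth inhibition staying within the scatter. No measurement at hand offers an explanation for this result.

On these data alone, whether an amine, a carboxylic acid or a longer alkoxy chain at the same carbon would also stay within the scatter remains open. So does the effect of methoxy on the other carbons of this ring.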